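The compounds below may be only part of what the source reports. "The series", "measured", "known", "first", "only" and "open" are said of these compounds alone.

Measured so far in a functional assay on HBL-100 cells (Homo sapiens) for cytotoxicity, read by MTT assay, with a stated time of 72 h; on this read-out higher numbers stand for weaker inhibition and lower numbers for stronger inhibition:
compound 1, `C#CCn1cc(C(=O)NC(CC(=O)Nc2ccccn2)c2ccccc2)c(=O)c2ccc(Cl)nc21`, a limit of the assay, > 10000 nM.
compound 2, `C#CCn1cc(C(=O)NC(CC(=O)NC2CCCC2)c2ccccc2)c(=O)c2ccc(Cl)nc21`, 3200 nM.
compound 3, `C#CCn1cc(C(=O)NC(CC(=O)Nc2ccccn2)c2ccccc2)c(=O)c2cc(F)c(Cl)nc21`, a limit of the assay, > 10000 nM.

The cores of compound 1 and compound 3 differ by fluoro in place of hydrogen on an aromatic carbon. The step that the two limits leave unreadable from compound 1 to compound 3, because both values sit at the limit of > 10000 nM in this assay, at which 2 of the 3 values shown sit.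

From compound 1 to compound 2 the change is cyclopentyl in place of pyridin-2-yl on an amide-type nitrogen, and it gives an at least 3.1-fold lower number from compound 1 to compound 2 (0.49 log units; beyond the scatter).

Compound 4, `C#CCn1cc(C(=O)NC(CC(=O)NC2CCCC2)c2ccccc2)c(=O)c2cc(F)c(Cl)nc21`, carries the same change on the core of compound 3: cyclopentyl in place of pyridin-2-yl on an amide-type nitrogen. In this assay the step from compound 3 to compound 4 is expected to be about an at least 2.5-fold lower number from compound 3 to compound 4 (0.39 log units; beyond the scatter), resting on the step seen from compound 1 to compound 2, an at least 3.1-fold lower number from compound 1 to compound 2 (0.49 log units; beyond the scatter), with the starting point of compound 3 being only a limit. Compound 4 is therefore estimated at 4000 nM, within a range from 1500 nM to 12000 nM.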

Compound 4, half-maximal inhibitory concentration: 2000 nM
The estimate for compound 4 lay 2.0-fold (0.30 log units) above the measured number; measured number inside the range.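

In this assay the change from pyridin-2-yl to cyclopentyl on the amide-type nitrogen also holds on the core of compound 3, with an at least 5.0-fold lower number from compound 3 to compound 4 (0.69 log units; beyond the scatter). The step points the same way on both cores: the same change on two cores in this assay, an at least 3.1-fold lower number (0.49 log units; beyond the scatter) from compound 1 to compound 2 and an at least 5.0-fold lower number (0.69 log units; beyond the scatter) from compound 3 to compound 4; the limit leaves it open whether they differ Compound 1 and compound 3 each stand at a limit and not at a number, so the full size of the step on either core remains unknown: the limit of > 10000 nM in this assay, at which 2 of the 4 values shown sit.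

Fluoro in place of hydrogen on an aromatic carbon gives a 1.6-fold lower number from compound 2 to compound 4 (0.20 log units; within the scatter), which leaves any effect of the fluoro unresolved in the cyclopentyl pair, and the step between the two pyridin-2-yl compounds cannot be read. On these data alone, it also remains open whether a cyclohexyl or an open-chain butyl on the same nitrogen would track cyclopentyl on both cores.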